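Notes on the aryl group at the carbonyl carbon

The compounds below may be only part of what the source reports. "The series", "measured", "known", "first", "only" and "open" are said of these compounds alone.

The three measured compounds share one core and differ only in the aryl group on the carbonyl carbon. In a functional assay on NCI-H460 cells (Homo sapiens) for antiproliferative activity, read by XTT assay, with a stated time of 72 h (on this read-out lower numbers stand for stronger inhibition and higher numbers for weaker inhibition), compound 1 `COc1ccc(-c2cc3ccccc3nc2/C=C/C(=O)c2ccc(F)cc2)cc1` gives 6990 nM, compound 2 `COc1ccc(-c2cc3ccccc3nc2/C=C/C(=O)c2c(OC)cccc2OC)cc1` gives 6630 nM, and compound 3 `COc1ccc(-c2cc3ccccc3nc2/C=C/C(=O)c2ccc(OC)c(OC)c2)cc1` gives 7540 nM. Compound 3 holds the top number of the three, yet a 1.1-fold higher number from compound 1 to compound 3 (0.03 log units; within the scatter) and a 1.1-fold higher number from compound 2 to compound 3 (0.06 log units; within the scatter) both sit within the scatter, as does a 1.1-fold lower number from compound 1 to compound 2 (0.02 log units; within the scatter). Compound 4 `COc1ccc(-c2cc3ccccc3nc2/C=C/C(=O)c2ccc([N+](=O)[O-])cc2)cc1` carries 4-nitrophenyl in place of 3,4-dimethoxyphenyl on a carbonyl carbon. For the measured compounds named here, the steps that bear on it, from compound 1 to compound 3 and from compound 2 to compound 3, were aryl swaps on the same carbonyl carbon, and neither moved this assay beyond the scatter; a nitro group is untested here. No step beyond the scatter is therefore expected, a 1.1-fold lower number from compound 3 to compound 4 (0.03 log units; within the scatter). Compound 4 is estimated at 7000 nM, within 3000 nM to 16000 nM.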

Compound 4, half-maximal inhibitory concentration: 6470 nM
Estimate against measurement, compound 4: 1.1-fold (0.03 log units) above, within the range that was stated.
By their numbers in this assay, from the lowest: compounds 4, 2, 1 and 3 (each within the scatter of the next).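

In this assay, the 4-nitrophenyl group on the carbonyl carbon stays within the scatter of all three earlier aryl groups (a 1.2-fold lower number from compound 3 to compound 4 (0.07 log units; within the scatter); a 1.0-fold lower number from compound 2 to compound 4 (0.01 log units; within the scatter); a 1.1-fold lower number from compound 1 to compound 4 (0.03 log units; within the scatter)). The nitro in place of fluoro comparison extends this flat picture to a single swap on the same aromatic carbon, so a nitro-bearing aryl group joins the fluoro and dimethoxy ones with no step beyond the scatter. No measurement is available that would explain this flatness.

Open, from the compounds shown here alone, is whether any group at this position moves the number beyond the scatter. An aryl group bearing an amine or a carboxylic acid, or a longer alkyl chain on the carbonyl carbon, would test this.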